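Hydrogen on the ring nitrogen of compound 3

A few compounds are considered here, and "the series" means these few. Any claim that something is new, unique, unknown or untested is made for them only; others in the source may bear on it.

Of the compounds shown here, three sharing one core have been measured in a functional assay on MCF7 cells (Homo sapiens) for antiproliferative activity, read by MTT assay, with a stated time of 72 h; on this read-out lower numbers stand for stronger inhibition and higher numbers for weaker inhibition. Compound 1 `COc1ccc(N2C(=O)COc3ccc(-c4cnc(Cl)c(NS(=O)(=O)c5ccc(F)cc5)c4)cc32)cc1` gives 36000 nM, compound 2 `CC(C)N1C(=O)COc2ccc(-c3cnc(Cl)c(NS(=O)(=O)c4ccc(F)cc4)c3)cc21` gives 26600 nM and compound 3 `O=C1COc2ccc(-c3cnc(Cl)c(NS(=O)(=O)c4ccc(F)cc4)c3)cc2N1c1ccc(F)cc1` gives 32600 nM. Compound 3 therefore lies within the scatter of both others. Compound 4 `O=C1COc2ccc(-c3cnc(Cl)c(NS(=O)(=O)c4ccc(F)cc4)c3)cc2N1` has hydrogen in place of 4-fluorophenyl on an amide-type nitrogen in a ring.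

Two measured steps exchange the group on this nitrogen: a 1.4-fold lower number from compound 1 to compound 2 (0.13 log units; within the scatter) and a 1.2-fold higher number from compound 2 to compound 3 (0.09 log units; within the scatter). The exchange on the aromatic carbon of the same group gives a 1.1-fold lower number from compound 1 to compound 3 (0.04 log units; within the scatter). All three lie within the scatter, but none leaves this nitrogen with only hydrogen, so the series has not yet tested that change. In this assay, no step beyond the scatter is expected, with wide margins on the estimate. The estimated step is a 1.1-fold lower number from compound 3 to compound 4 (0.04 log units; within the scatter). The estimate for compound 4 is 30000 nM, with an expected range of 13000 nM to 65000 nM.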

Compound 4, half-maximal inhibitory concentration: > 40000 nM
Compound 4 was reported as a limit (the forecaster's own chance of this, stated with the estimate: 15%); at least 1.3-fold (0.12 log units) between middle value and limit.
By their numbers in this assay, from the lowest: compounds 2, 3 and 1 (each within the scatter of the next). At a limit, above all of these: compound 4.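

In this assay, for the compounds shown here, the first compound with only hydrogen on this amide-type nitrogen, compound 4, is reported as a limit and not a number: the limit of > 40000 nM in this assay, at which 1 of the 4 values shown sits. Its steps can therefore be read only as floors (an at least 1.2-fold higher number from compound 3 to compound 4 (0.08 log units; that floor lies within the scatter); an at least 1.5-fold higher number from compound 2 to compound 4 (0.17 log units; that floor lies within the scatter); an at least 1.1-fold higher number from compound 1 to compound 4 (0.04 log units; that floor lies within the scatter)), and each floor lies within the scatter. Hydrogen in place of the isopropyl, 4-fluorophenyl or 4-methoxyphenyl group thus brings no sign of a gain, but a real loss is not established either.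

Going by these compounds, how far compound 4 actually stands from the substituted compounds remains open. Also open, on these data alone, is how this nitrogen responds to a methyl group, or to a longer chain ending in an amine or a carboxylic acid.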